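The source may report more compounds than this note shows. Statements on the series, on what has been measured and on what is new or still open speak of the compounds shown alone.

Among the measured compounds shown here, compound 1 `CC1CCN(c2ccc(Nc3nccc(-c4cccnc4)n3)cc2)CC1` carries the highest of the three numbers so far: in a functional assay for inhibition, with Homo sapiens as the target (a higher number here means a weaker inhibitor, a lower number a stronger inhibitor), compound 1 gives 500 nM. Compound 3 `CC1CCN(c2ccc(Nc3nccc(-c4cccs4)n3)cc2)CC1` gives 400 nM, and compound 2 `Nc1cccc(Nc2nccc(-c3ccccn3)n2)c1` gives 300 nM. Both gaps to compound 1 lie within the scatter, so no order among the three can be read from them. For the measured compounds named here, the only step between measured compounds that differ in a single place is a 1.3-fold lower number from compound 1 to compound 3 (0.10 log units; within the scatter), and it too stays within the scatter.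

Compound 4 `Oc1ccc(Nc2nccc(-c3cccnc3)n2)cc1` has not yet been measured. It differs from compound 1 in one place: hydroxy in place of 4-methylpiperidin-1-yl on an aromatic carbon. Going by the values given here, no measured step bears on this exchange. Among the compounds with values here, the one step in hand concerns the aromatic group on the other side of the shared core, and that change moved nothing beyond the scatter, which says nothing about the hydroxy group or the 4-methylpiperidin-1-yl group. With nothing to point in either direction, the expected step in this assay is a 1.2-fold higher number from compound 1 to compound 4 (0.08 log units; within the scatter), that is, none beyond the scatter, and the range is kept wide. Compound 4 is therefore estimated to give 600 nM, with a range from 150 nM to 2500 nM.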

Compound 4, half-maximal inhibitory concentration: 5100 nM
Compound 4: the middle estimate sits 8.5-fold (0.93 log units) below what was measured, and the stated range ends below it.
By their numbers in this assay, from the lowest: compounds 2, 3 and 1 (each within the scatter of the next); then compound 4.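

Among the compounds shown here, the exchange of 4-methylpiperidin-1-yl for hydroxy, on an aromatic carbon para to a large group, is the first change here to go beyond the scatter: in this assay it brings a 10-fold higher number from compound 1 to compound 4 (1.01 log units; beyond the scatter) and so marks this position as one where the choice of group matters. For the compounds shown here, the only earlier step, a 1.3-fold lower number from compound 1 to compound 3 (0.10 log units; within the scatter) for thiophen-2-yl in place of pyridin-3-yl, concerned a different place and stayed within the scatter. This single exchange replaces 7 heavy atoms and a six-membered non-aromatic ring with 1 heavy atom, no ring and 1 hydrogen-bond donor, so these differences change together, and no measurement here accounts for the step.

The compounds shown leave open whether a methoxy group, a dimethylamino group or a piperazine on this aromatic carbon would keep the number near that of compound 1 or move it towards that of compound 4. They also leave open whether the same exchange would have a similar size with thiophen-2-yl, the group carried by compound 3, in place of pyridin-3-yl.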